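Trading a Carbonyl Group for Fluorine

The compounds below may be only part of what the source reports. "The series", "measured", "known", "first", "only" and "open" are said of these compounds alone.

Compound 1, `CCc1ccc2oc(CSc3nnc(CNc4ccccc4)n3CC)nc2c1`, in an assay on isolated protein for inhibition of long-chain fatty acid transport protein 1 (Homo sapiens) (a higher number here means a weaker inhibitor, a lower number a stronger inhibitor), gives only a limit of the assay, > 1000 nM.
Compound 2, `CCn1c(CNc2ccccc2)nnc1SCC(=O)Nc1ccc(Cl)cc1`, in this assay also gives only a limit, > 1000 nM.
Compound 3, `CCn1c(CNc2ccccc2)nnc1SCc1nc2cc(C(=O)C(C)C)ccc2o1`, in this assay gives 600 nM.

For the measured compounds named here, compound 3 thus carries the only actual number of the three; the other two stop at a limit. The single measured step, an at least 1.6-fold lower number from compound 1 to compound 3 (0.22 log units; that floor lies within the scatter), replaces ethyl with isopropylcarbonyl and moves the number downward by at least the amount shown, although that floor lies within the scatter, since it starts from the limit of > 1000 nM in this assay, at which 2 of the 3 values shown sit.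

Compound 4, `CCn1c(CNc2ccccc2)nnc1SCc1nc2cc(F)ccc2o1`, differs from compound 3 in one place: fluoro in place of isopropylcarbonyl on an aromatic carbon. Going by the values given here, no measured step involves a fluoro group, and the one step touching this position only shows that the compound without isopropylcarbonyl, compound 1, sits at the limit. Removing that group again is therefore expected to push the number back up, a step estimated as a 2.5-fold higher number from compound 3 to compound 4 (0.40 log units; beyond the scatter). For compound 4 in this assay the expected value is 1500 nM, with a range from 600 nM to 4000 nM.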

Compound 4, half-maximal inhibitory concentration: > 1000 nM
Compound 4 was reported as a limit (the forecaster's own chance of this, stated with the estimate: 60%); the middle value is on the limit's open side.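

On this aromatic carbon, fluoro in place of isopropylcarbonyl gives an at least 1.6-fold higher number from compound 3 to compound 4 (0.22 log units; that floor lies within the scatter), so the change points upward, but its size can only be bounded and the bound alone does not clear the usual scatter. The step between compound 1 and compound 4 cannot be read, as both are limits, yet fluoro now joins ethyl in giving no actual number, leaving isopropylcarbonyl as the only group shown here that does. In this assay, compound 4 gives only a limit, not a number: the limit of > 1000 nM in this assay, at which 3 of the 4 values shown sit.

From the compounds shown here alone, how far the ethyl and fluoro compounds lie from compound 3 stays open, as does whether the carbonyl or the branched chain carries the difference. An acetyl group, a carboxylic acid or an amide on the same carbon could begin to separate these two parts.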